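Azido to methylsulfonyl: what to expect of compound 4

A few compounds are considered here, and "the series" means these few. Any claim that something is new, unique, unknown or untested is made for them only; others in the source may bear on it.

Values measured in a functional assay on MCF7 cells (Homo sapiens) for antiproliferative activity, read by MTT assay, with stated times of 24 h and 72 h (on this read-out lower numbers stand for stronger inhibition and higher numbers for weaker inhibition), are these
Compound 1 (`COc1ccc([C@@H]2[C@H](Oc3ccccc3)C(=O)N2c2cc(OC)c(OC)c(OC)c2)cc1`) at 35000 nM
Compound 2 (`COc1cccc([C@@H]2[C@H](Oc3ccccc3)C(=O)N2c2cc(OC)c(OC)c(OC)c2)c1`) at 171000 nM
Compound 3 (`COc1cc(N2C(=O)[C@@H](Oc3ccccc3)[C@H]2c2ccc(N=[N+]=[N-])cc2)cc(OC)c1OC`) at 23000 nM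

Compound 3 stands with compound 1 at the lower end of these three values. Among the compounds with values here, the data show a 1.5-fold lower number from compound 1 to compound 3 (0.18 log units; within the scatter) and so no ranking of that pair. Compound 2 lies apart, with a 7.4-fold lower number from compound 2 to compound 3 (0.87 log units; beyond the scatter) and also a 4.9-fold higher number from compound 1 to compound 2 (0.69 log units; beyond the scatter) in the data.

Compound 4 (`COc1cc(N2C(=O)[C@@H](Oc3ccccc3)[C@H]2c2ccc(S(C)(=O)=O)cc2)cc(OC)c1OC`) differs from compound 3 in one group. The difference is methylsulfonyl in place of azido on an aromatic carbon and amounts to methylsulfonyl in place of azido on an aromatic carbon, para to a large group.

The measured step most like this one is azido in place of methoxy on an aromatic carbon, which gave a 1.5-fold lower number from compound 1 to compound 3 (0.18 log units; within the scatter) and thus no shift that counts. The larger steps both involve the 3-methoxyphenyl of compound 2 and say little about this swap. Within the data shown here, no measured compound carries methylsulfonyl, so the range has to stay wide. No step beyond the scatter is expected in this assay, at most a slight drift towards a higher number. The expected result is a 1.3-fold higher number from compound 3 to compound 4 (0.12 log units; within the scatter) and no more than that. In this assay the estimate for compound 4 is 30000 nM with an expected range of 10000 nM to 90000 nM around it.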

Compound 4, half-maximal inhibitory concentration: 62000 nM
The estimate for compound 4 lay 2.1-fold (0.32 log units) below the measured number, and the stated range covers the measured number.
By their numbers in this assay, from the lowest: compounds 3, 1 and 4 (each within the scatter of the next, the first and the last beyond it); then compound 2.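

In this assay, the place para to a large group now proves sensitive to what sits on it: replacing azido with methylsulfonyl gives a 2.7-fold higher number from compound 3 to compound 4 (0.43 log units; beyond the scatter), a step beyond the scatter, whereas the earlier swap from methoxy to azido stayed within it. Methylsulfonyl and methoxy still cannot be ranked against each other, as the comparison shows (a 1.8-fold higher number from compound 1 to compound 4 (0.25 log units; within the scatter)), so compounds 1, 3 and 4 do not form a clean order: only the two ends, compound 3 and compound 4, are separated. The 4-(methylsulfonyl)phenyl compound also stays apart from the 3-methoxyphenyl compound (a 2.8-fold lower number from compound 2 to compound 4 (0.44 log units; beyond the scatter)), and nothing at hand gives a measured reason for any of these differences.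

The compounds shown leave open how an amine or a carboxylic acid would read at this place, and whether a longer chain such as ethylsulfonyl would behave like methylsulfonyl. They also leave open whether the swap from azido to methylsulfonyl would give a step of similar size on another core, since it is seen here in a single pair.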